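A few compounds are considered here, and "the series" means these few. Any claim that something is new, unique, unknown or untested is made for them only; others in the source may bear on it.

Working notes on the series. Compound 1 `O=c1cc(-c2ccccc2)oc2cc(N3COc4c(cccc4[N+](=O)[O-])C3)ccc12` gives 5.65% in a functional assay on MCF7 cells (Homo sapiens) for inhibition, read by MTT assay, with a stated time of 48 h, tested at 30 ug/mL (a lower number here means less inhibition of growth, a higher number more inhibition of growth at the concentration tested), the lowest of the three numbers in hand. Compound 3 `O=c1cc(-c2ccccc2)oc2cc(N3COc4c(Cl)cc(Cl)cc4C3)ccc12` gives 34.6% in this assay, a number beyond the scatter above compound 1, and compound 2 `O=c1cc(-c2ccccc2)oc2ccc(N3COc4ccccc4C3)cc12` gives 68.5%, the furthest from compound 1 and also beyond the scatter. No pair among these three differs in a single place, so no measured step is available. Compound 4 `O=c1cc(-c2ccccc2)oc2cc(N3COc4c(Br)cccc4C3)ccc12` differs from compound 1 by bromo in place of nitro on an aromatic carbon. A step upward beyond the scatter is expected for a number 29.4 percentage points higher from compound 1 to compound 4 (beyond the scatter), since compound 3, which carries halogens in the same core, gives 34.6%. Compound 4 is therefore estimated at 35%, with a range from 15% to 60%.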

Compound 4, percent growth inhibition at one concentration: 7.89%
The estimate for compound 4 lay 27.1 percentage points above the measured number, and the stated range ends above it.
By their numbers in this assay, from the lowest: compounds 1 and 4 (each within the scatter of the next); then compound 3; then compound 2.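

Bromo in place of nitro on this aromatic carbon gives a number 2.2 percentage points higher from compound 1 to compound 4 (within the scatter) in this assay, the only measured single-place step in the series. At this position, then, the read-out does not separate a nitro group of three heavy atoms from a single bromine. Nothing measured here bears on why the two groups read alike.

Going by these compounds, whether an amine or a carboxylic acid on this aromatic carbon would read apart from nitro and bromo remains open. Also open, on these data alone, is whether bromo and nitro read alike on the core of compound 2.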